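Thiophene to aminophenyl on a diarylpyrimidine: cytotoxicity outlook

A few compounds are considered here, and "the series" means these few. Any claim that something is new, unique, unknown or untested is made for them only; others in the source may bear on it.

Three compounds share a core and differ only in the group on the aromatic carbon two atoms from the ring nitrogen. Compound 1 `Cc1cc(C)cc(-c2cnc(Nc3ccc(C#N)cc3)nc2Oc2c(C)cc(C#N)cc2C)c1` gives 39000 nM in an ADME assay on MT4 cells (Homo sapiens) for cytotoxicity, read by MTT assay, with a stated time of 5 days; a lower number here means that less compound is tolerated, a higher number that more compound is tolerated. Compound 2 `Cc1cc(C#N)cc(C)c1Oc1nc(Nc2ccc(C#N)cc2)ncc1-c1ccc(Cl)cc1` gives 72600 nM, and a 1.9-fold higher number from compound 1 to compound 2 (0.27 log units; within the scatter). Compound 3 `Cc1cc(C#N)cc(C)c1Oc1nc(Nc2ccc(C#N)cc2)ncc1-c1ccsc1` gives 3920 nM, the lowest of the three numbers; a 9.9-fold lower number from compound 1 to compound 3 (1.00 log units; beyond the scatter) and a 19-fold lower number from compound 2 to compound 3 (1.27 log units; beyond the scatter).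

Compound 4 `Cc1cc(C#N)cc(C)c1Oc1nc(Nc2ccc(C#N)cc2)ncc1-c1ccc(N)cc1` differs from compound 3 by 4-aminophenyl in place of thiophen-3-yl on an aromatic carbon. The two steps that bear on this change both run from a six-membered carbon ring to thiophen-3-yl, and both lowered the number well beyond the scatter. Reversing that direction, a six-membered carbon ring entering in place of thiophen-3-yl, suggests the number for compound 4 should rise back toward the range of compounds 1 and 2. Within the data shown here, the 4-aminophenyl group has no measured precedent here, so the size of the rise is uncertain, but a change of the order seen in a 9.9-fold lower number from compound 1 to compound 3 (1.00 log units; beyond the scatter) is the natural expectation.

Compound 4 is therefore expected to give about 35000 nM, within a range of 9000 nM to 110000 nM. Compound 4 is thus expected to show an 8.9-fold higher number from compound 3 to compound 4 (0.95 log units; beyond the scatter).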

Compound 4, half-maximal cytotoxic concentration: 310 nM
The estimate for compound 4 lay 110-fold (2.05 log units) above the measured number, outside the stated range (below it).
By their numbers in this assay, from the lowest: compound 4; then compound 3; then compounds 1 and 2 (each within the scatter of the next).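

In this assay the position two atoms from the ring nitrogen turns out to respond strongly to what a six-membered carbon ring carries, since the exchange of chloro for amino alone gives a 230-fold lower number from compound 2 to compound 4 (2.37 log units; beyond the scatter). The change from 3,5-dimethylphenyl to 4-aminophenyl points the same way with a 130-fold lower number from compound 1 to compound 4 (2.10 log units; beyond the scatter), so compounds 1 and 2, whose numbers lie within the scatter of each other, do not describe six-membered carbon rings in general at this position. The earlier compounds left thiophen-3-yl with the lowest number, but 4-aminophenyl now goes beneath it with a 13-fold lower number from compound 3 to compound 4 (1.10 log units; beyond the scatter), so among these four compounds the ring type alone does not set the order.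

Nothing available here accounts for the drop in tolerated concentration. The compounds shown leave open whether the number depends on the amino group itself or on its place on the ring, and whether a hydroxy group, a dimethylamino group or an acetamide group on the same phenyl ring would give a similarly low number.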